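Widening the cyclobutanol to a dimethyl cyclohexanol

The compounds below may be only part of what the source reports. "The series", "measured", "known", "first", "only" and "open" are said of these compounds alone.

Compound 1 `N#Cc1cnc(NCc2cnccc2C(F)(F)F)cc1N[C@H]1C[C@@H](O)C1`: > 10000 nM
Compound 2 `N#Cc1cnc(NCc2ccccc2C(F)(F)F)cc1N[C@H]1C[C@H](C(N)=O)C1`: > 10000 nM
Compound 3 `CC1(C)C[C@H](Nc2cc(NCc3cnccc3C(F)(F)F)ncc2C#N)CC(C)(C)[C@H]1O`: 500 nM

In an assay on isolated protein for inhibition of protein kinase C delta type (Homo sapiens), read by TR-FRET, with a stated time of 2 h (a lower number here means a stronger inhibitor, a higher number a weaker inhibitor), compound 1 gives only > 10000 nM, which is a limit of the assay and not a number. Compound 2 likewise sits at a limit, > 10000 nM. Among the measured compounds shown here, compound 3 is the one compound with a measured number, 500 nM, so compound 1 stands at the limit of > 10000 nM in this assay, at which 2 of the 3 values shown sit, rather than at a value. The step to compound 4 `CC1(C)C[C@H](Nc2cc(NCc3cnccc3C(F)(F)F)ncc2C#N)CC[C@@H]1O` changes one place: 4-hydroxy-3,3-dimethylcyclohexyl in place of 3-hydroxycyclobutyl on a nitrogen on an aromatic ring. For the measured compounds named here, no measured pair shows this change, so the size of the step is a guess; with compound 3 at 500 nM a move toward stronger inhibition is expected. Compound 4 is estimated at 800 nM in this assay, between 200 nM and 4000 nM, a step of an at least 12-fold lower number from compound 1 to compound 4 (1.09 log units; beyond the scatter).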

Compound 4, half-maximal inhibitory concentration: 500 nM
The estimate for compound 4 lay 1.6-fold (0.20 log units) above the measured number; measured number inside the range.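

Replacing the small ring on this nitrogen with 4-hydroxy-3,3-dimethylcyclohexyl gives an at least 20-fold lower number from compound 1 to compound 4 (1.30 log units; beyond the scatter) and brings a measured value in this assay with the hydroxyl kept. The size of that step is only a bound, since compound 1 stands at a limit of the assay: the limit of > 10000 nM in this assay, at which 2 of the 4 values shown sit. With further methyl groups on the ring compound 3 gives 500 nM and compound 4 gives 500 nM as well.

The compounds shown do not separate ring size from the methyl groups, as a plain 4-hydroxycyclohexyl is not among them. Going by these compounds, whether an amine could stand in place of the hydroxyl also remains open.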